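Methyl for Methoxy on the Aryl Ring of Compound 2

A few compounds are considered here, and "the series" means these few. Any claim that something is new, unique, unknown or untested is made for them only; others in the source may bear on it.

Within the data shown here, compound 2 `C=C1C(=O)O[C@@H](C)[C@@H]1c1ccc(OC)cc1` gives the lower of the two numbers so far: in a functional assay on L1210 cells (Mus musculus) for cytotoxicity, read by MTT assay, with a stated time of 48 h (a lower number here means a stronger inhibitor, a higher number a weaker inhibitor), compound 2 gives 1950 nM, while compound 1 `C=C1C(=O)O[C@H](C)[C@@H]1c1ccc(OC)cc1` gives 4400 nM. Among the measured compounds shown here, the one measured step is a 2.3-fold lower number from compound 1 to compound 2 (0.35 log units; beyond the scatter), which rests on (the fact that compounds 1 and 2 differ only in the configuration as drawn). Compound 3 `C=C1C(=O)O[C@@H](C)[C@@H]1c1ccc(C)cc1` differs from compound 2 by methyl in place of methoxy on an aromatic carbon. For the measured compounds named here, no measured step concerns a change of this kind, as the known step touches configuration alone. For compound 3 the expected step is a 1.3-fold higher number from compound 2 to compound 3 (0.11 log units; within the scatter), likely within the scatter. In this assay compound 3 is estimated at 2500 nM, within a range from 800 nM to 8000 nM.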

Compound 3, half-maximal inhibitory concentration: 1500 nM
Beside the measured number, compound 3's estimate is 1.7-fold (0.22 log units) above it; low and high end bracket the measured number.
By their numbers in this assay, from the lowest: compounds 3 and 2 (each within the scatter of the next); then compound 1.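

In this assay, among these compounds, methyl in place of methoxy on the aromatic carbon gives a 1.3-fold lower number from compound 2 to compound 3 (0.11 log units; within the scatter), the first measured step at this position rather than in configuration. The swap removes the one hydrogen-bond acceptor of methoxy, yet compound 2 and compound 3 stay within the scatter of each other. Nothing in hand explains why these two groups read alike. The compounds shown leave open whether an amine, a carboxylic acid or a longer chain at this aromatic carbon would also stay level with methoxy and methyl.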